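The source may hold more compounds than are shown below. What is called first, only, known or untested is meant among the compounds shown, and "the series" means these compounds.

Measured so far in a functional assay on the whole organism (strain Jcl:SD) for inhibition, with Rattus norvegicus as the target, with stated times of 3 min and 3 h, at a dose of 1 mg/kg by the intravenous route; a higher number here means more inhibition at the dose given (going by the name of the read-out), a lower number less inhibition:
- compound 1, `CNCc1cc(-c2cccnc2F)n(S(=O)(=O)c2ccoc2)c1`: 82%
- compound 2, `CNCc1cc(-c2cccnc2F)n(S(=O)(=O)c2cccnc2)c1`: 96%
- compound 3, `CNCc1cc(-c2cccnc2F)n(S(=O)(=O)c2ccccn2)c1`: 81%

Compound 2 stands highest of the three in this assay; the step of a number 15 percentage points lower from compound 2 to compound 3 (beyond the scatter) and the step of a number 14 percentage points higher from compound 1 to compound 2 (beyond the scatter) both lie beyond the scatter, while the step of a number 1 percentage points lower from compound 1 to compound 3 (within the scatter) lies within it. All three measured steps concern the group on the sulfonyl sulfur only.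

Compound 4, `CNCc1cc(-c2cccnc2C#N)n(S(=O)(=O)c2cccnc2)c1`, keeps the sulfonyl group of compound 2 and differs from it elsewhere: cyano in place of fluoro on an aromatic carbon. The fluoro leaves and a cyano enters on the ring that carries the shared core. Among the compounds with values here, no measured step touches this ring, so nothing among the steps above tells how large a change to expect or in which direction. Within the data shown here, the only anchor is the value of compound 2, which already sits close to the top of the scale, leaving little room upward.

Compound 4 is therefore expected at about 85%, within 60% to 98%, a step of a number 11 percentage points lower from compound 2 to compound 4 (beyond the scatter) that is estimated with wide uncertainty.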

Compound 4, a percentage reported as inhibition, in the whole organism at one dose (the size of the read-out at that dose, not a potency): 48%
Compound 4: middle estimate off by 37 percentage points, on the high side; the measured number lies below the stated range.
By their numbers in this assay, from the lowest: compound 4; then compounds 3 and 1 (each within the scatter of the next); then compound 2.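

In this assay the change from 2-fluoropyridin-3-yl to 2-cyanopyridin-3-yl gives a number 48 percentage points lower from compound 2 to compound 4 (beyond the scatter) and so outweighs each step seen at the sulfonyl group. With the sulfonyl group held as in compound 2, the outcome in this test depends strongly on which group sits at this carbon, next to the ring nitrogen and ortho to a large group. Nothing measured here explains the drop.

Among the compounds shown, only fluoro and cyano appear at this carbon, so this one pair cannot tell whether the loss is particular to cyano or would recur with groups such as chloro, methyl or methoxy. It also leaves open whether the same swap would cost as much with the sulfonyl groups of compound 1 and compound 3.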